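Replacing the 2-(diethylamino)ethyl group on the amide nitrogen

The compounds below may be only part of what the source reports. "The series", "measured", "known", "first", "only" and "open" are said of these compounds alone.

In a functional assay on MCF7 cells (Homo sapiens) for antiproliferative activity, read by MTT assay, with a stated time of 24 h (a higher number here means a weaker inhibitor, a lower number a stronger inhibitor), compound 2 (`CCN(CC)CCNC(=O)c1ccc(C(CC)(CC)c2ccc(OCS(=O)(=O)c3ccccc3)c(C)c2)n1CC`) gives 4680 nM, which lies within the scatter of compound 1 (`CCn1c(C(=O)NCCN)ccc1C(CC)(CC)c1ccc(OCS(=O)(=O)c2ccccc2)c(C)c1`) at 6470 nM. Compound 3 (`CCn1c(C(=O)NC(C)(C)CO)ccc1C(CC)(CC)c1ccc(OCS(=O)(=O)c2ccccc2)c(C)c1`) carries 1-(hydroxymethyl)-1-methylethyl in place of 2-(diethylamino)ethyl on an amide-type nitrogen. Among the measured compounds shown here, only one measured step bears on this change: a 1.4-fold lower number from compound 1 to compound 2 (0.14 log units; within the scatter). That step altered the end of the chain but kept its nitrogen, whereas the entering group has oxygen and no nitrogen, so it is only a partial guide. With that caution, no step beyond the scatter is expected in this assay, and no direction can be firmly assigned. The estimated step is a 1.2-fold higher number from compound 2 to compound 3 (0.07 log units; within the scatter). Compound 3 is expected at about 5500 nM, with an estimated range of 2200 nM to 14000 nM.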

Compound 3, half-maximal inhibitory concentration: 20700 nM
Compound 3: the middle estimate sits 3.8-fold (0.58 log units) below what was measured; the measured number lies above the stated range.
By their numbers in this assay, from the lowest: compounds 2 and 1 (each within the scatter of the next); then compound 3.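

In this assay the group on the amide-type nitrogen proves not to be indifferent, although the change at the end of the chain in the earlier pair had stayed within the scatter. Putting 1-(hydroxymethyl)-1-methylethyl in place of 2-(diethylamino)ethyl gives a 4.4-fold higher number from compound 2 to compound 3 (0.65 log units; beyond the scatter) in this series, and putting it in place of 2-aminoethyl gives a 3.2-fold higher number from compound 1 to compound 3 (0.51 log units; beyond the scatter) in the same direction. Nothing measured here accounts for this rise.

As far as these compounds go, the entering group differs from both chains in more than one feature, so it stays open whether the loss of the chain nitrogen, the hydroxyl or the branching carries the step. A 2-hydroxyethyl group or a 2-amino-1,1-dimethylethyl group on the same nitrogen would separate these features.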